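The compounds below may be only part of what the source reports. "The series", "measured", "known", "first", "only" and "open" are said of these compounds alone.

In a functional assay on MCF7 cells (Homo sapiens) for antiproliferative activity, read by CellTiter-Glo, with a stated time of 5 days (on this read-out higher numbers stand for weaker inhibition and lower numbers for stronger inhibition), compound 1 `CC/C(=C(/c1ccc(/C=C/C(=O)O)cc1)c1ccc2c(cnn2C)c1)c1ccccc1` gives 300 nM and compound 2 `CC/C(=C(/c1ccc(/C=C/C(=O)O)cc1)c1ccc(-c2nccs2)cc1)c1ccccc1` gives 290 nM on the same measure. Compound 2 therefore stands within the scatter of compound 1, and the two cannot be ranked. Compound 3 `CC/C(=C(/c1ccc(/C=C/C(=O)O)cc1)c1ccc(-c2cn[nH]c2)cc1)c1ccccc1` keeps the shared core and carries 1H-pyrazol-4-yl in place of 1,3-thiazol-2-yl on an aromatic carbon, para to a large group. The change counts as 1H-pyrazol-4-yl in place of 1,3-thiazol-2-yl on an aromatic carbon at that one place. Among the measured compounds shown here, no measured pair isolates this change, so its size rests on expectation alone. In this assay a modest move toward stronger inhibition is expected, though a result within the scatter of compound 2 remains possible. The estimated 2.4-fold lower number from compound 2 to compound 3 (0.38 log units; beyond the scatter) points that way. For compound 3 the expected value is 120 nM with an estimated range from 30 nM to 400 nM on repeat measurement.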

Compound 3, half-maximal inhibitory concentration: 40 nM
Estimate against measurement, compound 3: 3.0-fold (0.48 log units) above; measured number inside the range.
By their numbers in this assay, from the lowest: compound 3; then compounds 2 and 1 (each within the scatter of the next).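

In this assay, among the compounds shown here, the exchange of 1,3-thiazol-2-yl for 1H-pyrazol-4-yl on an aromatic carbon, para to a large group, gives a 7.3-fold lower number from compound 2 to compound 3 (0.86 log units; beyond the scatter) and is the only step available so far. It shows that this position responds to the identity of the five-membered aromatic ring, even though both groups have 5 heavy atoms and 2 hetero atoms. The step changes the sulfur, the hydrogen-bond donor count and the hydrogen-bond acceptor count together, and no measurement at hand explains its size.
Still open, going by these compounds, is whether the ring nitrogen hydrogen of compound 3 matters, which a 1-methyl-1H-pyrazol-4-yl or an imidazolyl group at this place would test. The compounds shown also leave open how far the step carries over when an amide replaces the carboxylic acid.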